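The compounds below may be only part of what the source reports. "The series", "measured", "known", "first", "only" and "open" are said of these compounds alone.

Measured in an ADME assay on Vero cells (Chlorocebus sabaeus) for cytotoxicity; on this read-out lower numbers stand for higher toxicity in this test and higher numbers for lower toxicity in this test:
Compound 1 `CCOc1ccccc1-c1nc2ccncc2s1`: > 50000 nM (a limit)
Compound 2 `c1ccc(Oc2ccccc2-c2nc3ccncc3s2)cc1`: > 50000 nM (a limit)
Compound 3 `c1ccc(-c2nc3ccncc3s2)c(OCCC2CCOCC2)c1`: > 50000 nM (a limit)

Compound 2 stands with the other two compounds on the same limit: the limit of > 50000 nM in this assay, at which 3 of the 3 values shown sit. Compound 4 `CC(=O)Nc1ccc(Oc2ccccc2-c2nc3ccncc3s2)cc1` differs from compound 2 by one change: acetamido in place of hydrogen on an aromatic carbon. Going by the values given here, the steps that bear on it are a step that the two limits leave unreadable from compound 1 to compound 2, a step that the two limits leave unreadable from compound 1 to compound 3 and a step that the two limits leave unreadable from compound 2 to compound 3. None of them has a readable size, and none involves an acetamido group, so they offer only a weak guide. No shift in either direction beyond the usual scatter is expected in this assay, and the estimated outcome is a number no higher from compound 2 to compound 4 (the limit leaves the size open). The estimate for compound 4 is 50000 nM, with an expected range from 20000 nM to 100000 nM.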

Compound 4, half-maximal cytotoxic concentration: > 50000 nM
Compound 4 gave a limit, no number; the forecaster's own chance of this, stated with the estimate: 75%; the middle value sits exactly at the limit.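

The step from compound 2 to compound 4 cannot be read in this assay, since both compounds sit on a limit: the limit of > 50000 nM in this assay, at which 4 of the 4 values shown sit.

The compounds shown leave open where any of the four would give an actual number, and whether acetamido in place of hydrogen shifts the read-out at all.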